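The source may hold more compounds than are shown below. What is called first, only, known or untested is meant among the compounds shown, and "the series" means these compounds.

Compound 1 `CC(C)CNC(=O)[C@H](C)NC(=O)[C@@]1(Cc2ccccc2)CCN1C(=O)OCc1ccccc1` sets the shared core of the series. In an ADME assay on HELF cells (Homo sapiens) for cytotoxicity, with a stated time of 3 days (a lower number here means that less compound is tolerated, a higher number that more compound is tolerated), compound 1 reaches only a limit, > 100000 nM. Compound 3 `C[C@H](NC(=O)[C@@]1(Cc2ccccc2)CCN1C(=O)OCc1ccccc1)C(=O)NCc1ccccc1` likewise gives only a limit in this assay, >= 20000 nM. The step that the two limits leave unreadable from compound 1 to compound 3 therefore cannot be read. Within the data shown here, compound 2 `C[C@H](NC(=O)[C@]1(Cc2ccccc2)CCN1C(=O)OCc1ccc([N+](=O)[O-])cc1)C(N)=O` is the one compound with a number in this assay, where compound 2 gives 100000 nM. Compound 4 `C[C@H](NC(=O)[C@]1(Cc2ccccc2)CCN1C(=O)Oc1cccc2ccccc12)C(N)=O` differs from compound 2 in this way: naphthalen-1-yl in place of 4-nitrobenzyl on an oxygen next to a carbonyl group. Among the measured compounds shown here, no measured step changes the group on an oxygen next to a carbonyl group, so neither size nor direction is set by the measured steps; the only bearings are the limit of > 100000 nM in this assay, at which 1 of the 3 values shown sits, and (the limit of >= 20000 nM in this assay, at which 1 of the 3 values shown sits). The step from compound 2 is expected to be a 1.3-fold lower number from compound 2 to compound 4 (0.10 log units; within the scatter). Compound 4 is estimated at 80000 nM, between 20000 nM and 200000 nM.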

Compound 4, minimum cytotoxic concentration: > 100000 nM
Compound 4: no number, only a limit; the forecaster's own chance of this, stated with the estimate: 40%; middle value at least 1.2-fold (0.09 log units) away from the limit.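

Compound 4 gives only a limit in this assay: the limit of > 100000 nM in this assay, at which 2 of the 4 values shown sit.

Naphthalen-1-yl in place of 4-nitrobenzyl, the only measured change on this oxygen next to a carbonyl group, gives a number no lower from compound 2 to compound 4 (the limit leaves the size open). At this place, then, 2 six-membered aromatic rings of carbon only and 0 hydrogen-bond acceptors bring no lower number in this assay.

On these data alone, the size of this step stays open beyond its direction. Also open, as far as these compounds go, is what a longer alkyl chain or an aryl group carrying a carboxylic acid would do at this place.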